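The compounds below may be only part of what the source reports. "The series", "measured", "known", "first", "only" and "open" are said of these compounds alone.

Series notes. Compound 1 `Cn1c(N2N=C(c3ccccc3)CC2c2ccccc2)nc(-c2ccccc2)c(C#N)c1=O` gives 2490 nM in a functional assay on HT-29 cells (Homo sapiens) for antiproliferative activity, with a stated time of 72 h; on this read-out higher numbers stand for weaker inhibition and lower numbers for stronger inhibition. Compound 2 `Cn1c(N2N=C(c3ccc(Cl)cc3)CC2c2ccccc2)nc(-c2ccccc2)c(C#N)c1=O` gives 6600 nM in this assay, and compound 3 `COc1ccc(C2CC(c3ccc(Cl)cc3)=NN2c2nc(-c3ccccc3)c(C#N)c(=O)n2C)cc1` gives 9120 nM. Compound 2 thus stands second highest of the three numbers, beyond the scatter from compound 1 and within it of compound 3. Compound 4 `Cn1c(N2N=C(c3ccc(Cl)cc3)CC2c2ccccc2)nc(-c2ccc(Cl)cc2)c(C#N)c1=O` differs from compound 2 by chloro in place of hydrogen on an aromatic carbon. The step that bears most directly on this is a 2.7-fold higher number from compound 1 to compound 2 (0.42 log units; beyond the scatter), a chloro added to a phenyl of the same core; a 1.4-fold higher number from compound 2 to compound 3 (0.14 log units; within the scatter) adds a different group and weighs less. For compound 4 a modest rise in the number is therefore expected, a 1.6-fold higher number from compound 2 to compound 4 (0.20 log units; within the scatter). Compound 4 is estimated at 10500 nM, with a range from 4500 nM to 25000 nM.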

Compound 4, half-maximal inhibitory concentration: 8720 nM
Estimate against measurement, compound 4: 1.2-fold (0.08 log units) above, within the range that was stated.
By their numbers in this assay, from the lowest: compound 1; then compounds 2, 4 and 3 (each within the scatter of the next).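

In this assay, chloro in place of hydrogen on this phenyl, para to a large group, gives a 1.3-fold higher number from compound 2 to compound 4 (0.12 log units; within the scatter), whereas the same change on the other phenyl gave a 2.7-fold higher number from compound 1 to compound 2 (0.42 log units; beyond the scatter). At this position, with the first chloro already present, phenyl to 4-chlorophenyl therefore shifts the number by no more than the usual scatter. Nothing available explains the difference between the two steps. The compounds shown leave open how this chloro behaves without the first chloro. They also leave open whether an amine or a carboxylic acid here would move the number beyond the scatter.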